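Sulfonamide series: trifluoromethyl for methyl on compound 2

A few compounds are considered here, and "the series" means these few. Any claim that something is new, unique, unknown or untested is made for them only; others in the source may bear on it.

Three compounds share the core: compound 1, `CC1CCN(C2CCN(S(=O)(=O)c3cccnc3Cl)CC2)CC1`, compound 2, `Cc1ccc(-c2ccccc2S(=O)(=O)N2CCC(N3CCC(C)CC3)CC2)cc1`, and compound 3, `CC1CCCN(C2CCN(S(=O)(=O)c3ccc(OC(F)F)cc3)CC2)C1`. In a functional assay on DLD-1 cells (Homo sapiens) for antiproliferative activity, read by CellTiter-Glo, with a stated time of 72 h (on this read-out lower numbers stand for stronger inhibition and higher numbers for weaker inhibition), compound 2 gives 366 nM. Compound 3 gives 105 nM in this assay, a lower number that lies beyond the scatter. For compound 1 the read-out is a limit of the assay and not a number, > 5000 nM; see (the limit of > 5000 nM in this assay, at which 1 of the 3 values shown sits). Among the two numbers shown, compound 2 therefore stands highest, with compound 3 its nearest neighbour.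

Compound 4, `CC1CCN(C2CCN(S(=O)(=O)c3ccccc3-c3ccc(C(F)(F)F)cc3)CC2)CC1`, is not yet measured. It differs from compound 2 by trifluoromethyl in place of methyl on an aromatic carbon, the change sitting on an aromatic carbon of a six-membered aromatic ring of carbon only, para to a large group. For the measured compounds named here, no measured pair in the set covers this exchange, so no direction can be read from the data; the expected step in this assay is small, likely within the scatter, with no strong lean either way. Compound 4 is estimated at 320 nM, between 110 nM and 950 nM. This estimate means a step of a 1.1-fold lower number from compound 2 to compound 4 (0.06 log units; within the scatter), expected rather than known.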

Compound 4, half-maximal inhibitory concentration: 122 nM
Estimate against measurement, compound 4: 2.6-fold (0.42 log units) above; the measured number falls inside the stated range.
By their numbers in this assay, from the lowest: compounds 3 and 4 (each within the scatter of the next); then compound 2. At a limit, above all of these: compound 1.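

In this assay, for the compounds shown here, the change from 4-methylphenyl to 4-(trifluoromethyl)phenyl gives a 3.0-fold lower number from compound 2 to compound 4 (0.48 log units; beyond the scatter), the only step so far that can be read between two measured compounds. It shows that the number responds to the group on this aromatic carbon, para to a large group, and that trifluoromethyl, the larger of the two groups by heavy atoms, goes with the lower number here. Nothing in the data shown accounts for this step.

From the compounds shown here alone, the result rests on a single pair, so whether a chlorine, a methoxy group, a nitrile or a carboxylic acid on this carbon would continue the step remains open. Also open, going by these compounds, is whether the same exchange gives a similar step with other amines on the shared core.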